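Trimming One Methoxy Group from Compound 2

The source may hold more compounds than are shown below. What is called first, only, known or untested is meant among the compounds shown, and "the series" means these compounds.

Compound 2, `COc1cc(-c2cc(/C=C/C(=O)c3ccc(N)cc3)[nH]n2)cc(OC)c1OC`, was tested in a functional assay on COLO 205 cells (Homo sapiens) for cytotoxicity, read by sulforhodamine B assay, with a stated time of 48 h, tested at 1 uM (on this read-out higher numbers stand for a weaker effect at the one concentration tested and lower numbers for a stronger effect), where compound 2 gives 92%. Among the compounds with values here, on the numbers measured so far, compound 2 stands as the lower of two, but only by a margin within the usual scatter: its nearest neighbour, compound 1, `COc1ccc(-c2cc(/C=C/C(=O)c3ccc(N)cc3)[nH]n2)cc1`, gives 100%, so the two cannot really be told apart. Compound 3, `COc1ccc(-c2cc(/C=C/C(=O)c3ccc(N)cc3)[nH]n2)cc1OC`, has not yet been measured in this assay. It differs from compound 2 in one place: hydrogen in place of methoxy on an aromatic carbon. Compound 2 shows 92% and compound 1 shows 100%, both near the top of the scale, and nothing separates them beyond the scatter. The expected step, a number 3 percentage points higher from compound 2 to compound 3 (within the scatter), is therefore small and in no set direction, staying within the scatter. Compound 3 is estimated to give 95%, within a range from 80% to 106%.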

Compound 3, a percentage reported as activity, at one concentration (the size of the read-out at that concentration, not a potency): 98%
For compound 3 the middle estimate is 3 percentage points below the measured one, and the stated range covers the measured number.
By their numbers in this assay, from the lowest: compounds 2, 3 and 1 (each within the scatter of the next).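

Swapping this methoxy for hydrogen gives a number 6 percentage points higher from compound 2 to compound 3 (within the scatter) in this assay and so does not separate the two compounds. Read from the other side, methoxy in place of hydrogen on an aromatic carbon gives a number 2 percentage points lower from compound 1 to compound 3 (within the scatter) and again stays inside the normal spread of repeat measurements. At this single concentration, therefore, this methoxy group can be present or absent with no change that the read-out can distinguish, and no measurement at hand gives a reason for this.

Going by these compounds, whether an amine, a carboxylic acid or a longer chain such as ethoxy on this aromatic carbon would move the number beyond the scatter remains open. A single concentration also leaves open whether these compounds would show a stronger or weaker effect than one another at other concentrations.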